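This account rests on a few compounds, and the source may have more. Where it says the series, first, only, none or still open, it means among the compounds named here.

In a functional assay on MT4 cells (Homo sapiens) (a lower number here means that less compound is tolerated, a higher number that more compound is tolerated), three compounds have been tested so far. For compound 1 `Cc1cn([C@@H]2O[C@@H]3COC(=O)[C@]3(OS(C)(=O)=O)[C@H]2O)c(=O)[nH]c1=O` the assay reports only a limit, >= 250000 nM. Compound 2 `C=C(C)C(=O)NC(=O)NC1=CS(=O)(=O)O[C@@]12[C@@H](CO[Si](C)(C)C(C)(C)C)O[C@@H](n1cc(C)c(=O)n(C)c1=O)[C@@H]2O[Si](C)(C)C(C)(C)C` gives 1190 nM, and compound 3 `COC(=O)NC1=CS(=O)(=O)O[C@@]12[C@@H](CO[Si](C)(C)C(C)(C)C)O[C@@H](n1cc(C)c(=O)n(C)c1=O)[C@@H]2O[Si](C)(C)C(C)(C)C` gives 29900 nM. Compound 2 therefore holds the lower of the two actual numbers, and its nearest neighbour is compound 3.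

Compound 4 `Cc1cn([C@@H]2O[C@H](CO[Si](C)(C)C(C)(C)C)[C@@]3(OS(=O)(=O)C=C3NC(=O)c3ccccc3)[C@H]2O[Si](C)(C)C(C)(C)C)c(=O)n(C)c1=O` keeps the rest of compound 2 and changes one group: phenyl in place of ((1-methylethenyl)carbonyl)amino on a carbonyl carbon.

Within the data shown here, one measured step bears on this change: a 25-fold higher number from compound 2 to compound 3 (1.40 log units; beyond the scatter), a large step in which methoxy replaces the same group on a carbonyl carbon. Going by compound 3 at 29900 nM, a rise is expected here too. Among the measured compounds shown here, it is expected to be smaller, with only that one step to go on and phenyl not being methoxy. The expected change is a 6.7-fold higher number from compound 2 to compound 4 (0.83 log units; beyond the scatter). Compound 4 is estimated at 8000 nM, with an expected range of 1500 nM to 40000 nM.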

Compound 4, half-maximal cytotoxic concentration: 4900 nM
For compound 4 the middle estimate is 1.6-fold (0.21 log units) above the measured one; the measured number falls inside the stated range.
By their numbers in this assay, from the lowest: compound 2; then compound 4; then compound 3. At a limit, above all of these: compound 1.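

In this assay phenyl on the carbonyl carbon gives a 4.1-fold higher number from compound 2 to compound 4 (0.61 log units; beyond the scatter) and so a second replacement of ((1-methylethenyl)carbonyl)amino moves the number in the same direction as methoxy did. Phenyl and methoxy also differ from each other, with a 6.1-fold lower number from compound 3 to compound 4 (0.79 log units; beyond the scatter) showing that the group entering at this carbonyl carbon matters, not only the group leaving. Nothing measured here explains either difference.

From the compounds shown here alone, with only two replacements to compare, it remains open whether the higher numbers follow from losing ((1-methylethenyl)carbonyl)amino in general or depend on each entering group. An amine, a carboxylic acid or a longer alkyl chain on the same carbonyl carbon could show whether the number can go above that of compound 3 or fall back towards that of compound 2.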